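This account rests on a few compounds, and the source may have more. Where it says the series, first, only, none or still open, it means among the compounds named here.

Series notes. Within the data shown here, compound 2 `O=C(c1ccc(OCCCN2CC[C@H](NS(=O)(=O)c3cccc(Cl)c3)C2)cc1)C1CC1` gives 700 nM in an assay on isolated protein for binding affinity to histamine H2 receptor (Homo sapiens) (a lower number here means a stronger inhibitor, a higher number a weaker inhibitor), the second highest of the three numbers so far. Compound 1 `CCc1ccc(S(=O)(=O)N[C@H]2CCN(CCCOc3ccc(C(=O)C4CC4)cc3)C2)cc1` stands nearest, at 330 nM; compound 3 `CC(=O)c1ccc(OCCCN2CC[C@H](NC(=O)c3csc(-c4cccnc4)n3)C2)cc1` stands furthest, at 6200 nM. Among the measured compounds shown here, the only measured step that turns on the group attached to the sulfonyl sulfur is a 2.1-fold higher number from compound 1 to compound 2 (0.33 log units; beyond the scatter), a modest change. Compound 4 `Cc1ccccc1S(=O)(=O)N[C@H]1CCN(CCCOc2ccc(C(=O)C3CC3)cc2)C1` is the next member awaiting measurement; its difference from compound 2 is 2-methylphenyl in place of 3-chlorophenyl on a sulfonyl sulfur. For the measured compounds named here, no measured compound carries the 2-methylphenyl group, so the expectation for compound 4 rests on the single aryl swap seen in a 2.1-fold higher number from compound 1 to compound 2 (0.33 log units; beyond the scatter), which stayed small. A step of similar size is therefore expected, more likely back toward the number of compound 1 than further away from it, and the step expected from compound 2 to compound 4 is a 1.4-fold lower number from compound 2 to compound 4 (0.15 log units; within the scatter). Compound 4 is expected at 500 nM in this assay, within a range from 200 nM to 1300 nM.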

Compound 4, inhibition constant: 2200 nM
For compound 4 the middle estimate is 4.4-fold (0.64 log units) below the measured one, and the stated range ends below it.
By their numbers in this assay, from the lowest: compound 1; then compound 2; then compound 4; then compound 3.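

In this assay, among these compounds, the group on the sulfonyl sulfur moves the number further than the single earlier aryl swap showed: 2-methylphenyl in place of 3-chlorophenyl gives a 3.1-fold higher number from compound 2 to compound 4 (0.50 log units; beyond the scatter) and 2-methylphenyl in place of 4-ethylphenyl gives a 6.7-fold higher number from compound 1 to compound 4 (0.82 log units; beyond the scatter) on the same core. This position therefore does not treat all aryl groups alike, and with three aryl groups compared, the order from the lowest number is compound 1, compound 2, compound 4. Nothing available here bears on what lies behind this shift.

Open, on these data alone, is whether an unsubstituted phenyl or a saturated cyclohexyl on the sulfonyl sulfur would stand nearer to compound 1 or to compound 4. Also open, as far as these compounds go, is whether this order of aryl groups would hold with a carboxylic acid in place of the cyclopropyl ketone.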